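A few compounds are considered here, and "the series" means these few. Any claim that something is new, unique, unknown or untested is made for them only; others in the source may bear on it.

Values in a functional assay on CCRF-CEM cells (Homo sapiens) for inhibition, read by MTT assay, with a stated time of 72 h; on this read-out higher numbers stand for weaker inhibition and lower numbers for stronger inhibition:
compound 1 `COc1cc(NC(C)CCCNC(=O)Nc2cccc(Cl)c2)c2ncccc2c1`: 22000 nM
compound 2 `COc1cc(NC(C)CCCNC(=O)NNC(=O)Nc2ccc(Cl)cc2)c2ncccc2c1`: 108000 nM
compound 3 `COc1cc(NC(C)CCCNC(=O)Nc2ccc(F)cc2)c2ncccc2c1`: 26000 nM

Compound 3 stands level with compound 1 at the low end of the set, well short of compound 2. Next is compound 4 `COc1cc(NC(C)CCCNC(=O)NNC(=O)Nc2ccc(Br)cc2)c2ncccc2c1`. The change is ((4-bromophenyl)carbamoyl)amino in place of 4-fluorophenyl on an amide-type nitrogen. Among the measured compounds shown here, compound 2 is the only measured compound with a comparable group, so two modest steps bear on this: a 4.9-fold higher number from compound 1 to compound 2 (0.69 log units; beyond the scatter) and a 4.2-fold lower number from compound 2 to compound 3 (0.62 log units; beyond the scatter). The aryl swap in a 1.2-fold higher number from compound 1 to compound 3 (0.07 log units; within the scatter) stays within the scatter. For the measured compounds named here, no bromo compound has been measured. In this assay, a rise of similar size is expected, estimated as a 3.8-fold higher number from compound 3 to compound 4 (0.59 log units; beyond the scatter). Compound 4 is expected at 100000 nM, with an estimated range of 50000 nM to 200000 nM.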

Compound 4, half-maximal inhibitory concentration: 110000 nM
Estimate against measurement, compound 4: 1.1-fold (0.04 log units) below; measured number inside the range.
By their numbers in this assay, from the lowest: compounds 1 and 3 (each within the scatter of the next); then compounds 2 and 4 (each within the scatter of the next).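

In this assay, bromo in place of chloro on an aromatic carbon gives a 1.0-fold higher number from compound 2 to compound 4 (0.01 log units; within the scatter), so this halogen exchange leaves the number unmoved within the carbamoylamino-bearing pair. On the amide-type nitrogen, ((4-bromophenyl)carbamoyl)amino gives a 4.2-fold higher number from compound 3 to compound 4 (0.63 log units; beyond the scatter) and a 5.0-fold higher number from compound 1 to compound 4 (0.70 log units; beyond the scatter), so compounds 2 and 4 both stand apart from compounds 1 and 3, with neither going against this split. No available data explain this split. Going by these compounds, how a carboxylic acid or an amine in place of 4-fluorophenyl on the amide-type nitrogen would read remains open.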